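A few compounds are considered here, and "the series" means these few. Any claim that something is new, unique, unknown or untested is made for them only; others in the source may bear on it.

Compound 1, `CNC(=O)c1cc(C(=O)NC2CCC2)cn(Cc2ccncc2)c1=O`, has been tested in a physicochemical assay for solubility; on this read-out lower numbers stand for lower solubility and higher numbers for higher solubility. In this assay compound 1 gives >= 118 ug/mL, which is a limit of the assay and not a number. Compound 2, `CNC(=O)c1cc(C(=O)NC2CC2)c(C)n(Cc2ccccc2)c1=O`, carries a benzyl group in place of the (pyridin-4-yl)methyl group and has a cyclopropyl amide and an extra methyl on the core. In this assay compound 2 gives >= 126 ug/mL, again a limit of the assay rather than a number. Both measured compounds thus stand at a limit, as shown by the limit of >= 118 ug/mL in this assay, at which 1 of the 2 values shown sits, and (the limit of >= 126 ug/mL in this assay, at which 1 of the 2 values shown sits), so no measured step between them can be read.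

Compound 3, `CNC(=O)c1cc(C(=O)NC2CCC2)cn(Cc2ccccc2)c1=O`, differs from compound 1 in one place: phenyl in place of pyridin-4-yl on a saturated chain carbon bound to an aromatic nitrogen

Within the data shown here, no measured step covers this change. Compound 3 is expected to show a step from compound 1 of an at least 1.1-fold lower number from compound 1 to compound 3 (0.07 log units; that floor lies within the scatter), small and within the usual scatter, since compound 2, which also carries a benzyl group, likewise sits at a limit in this assay. For compound 3 the estimated solubility is 100 ug/mL, with a range from 40 ug/mL to 200 ug/mL.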

Compound 3, solubility: 28 ug/mL
Estimate against measurement, compound 3: 3.6-fold (0.55 log units) above; the whole stated range lies above it.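

Among these compounds, with phenyl in place of pyridin-4-yl on a saturated chain carbon bound to an aromatic nitrogen, this assay gives the first readable step at this position: an at least 4.2-fold lower number from compound 1 to compound 3 (0.62 log units; beyond the scatter). Among the compounds shown here, the two groups have the same count of heavy atoms, and the counted difference is that the ring nitrogen of pyridin-4-yl, a hydrogen-bond acceptor, gives way to carbon, so this small edit is the only thing separating the two compounds, whereas compound 2 differs from each of them in more than one place and no step to it can be read. The step is only a floor, and the real gap may be larger, because compound 1 stands at a limit of the assay and not at a number: the limit of >= 118 ug/mL in this assay, at which 1 of the 3 values shown sits.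

The compounds shown leave open whether a phenyl ring carrying an amine or a carboxylic acid at this position would restore the higher read-out that compound 1 shows. They also leave open whether the same exchange gives a step of similar size when the rest of the molecule changes, for example with a different amide on the shared core.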